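The source may report more compounds than this note shows. Statements on the series, on what has been measured and on what is new or still open speak of the compounds shown alone.

Working notes on the series. In an ADME assay on MT4 cells (Homo sapiens) for cytotoxicity, read by MTT assay, with a stated time of 4 days (on this read-out lower numbers stand for higher toxicity in this test and higher numbers for lower toxicity in this test), compound 1 (`Cc1c(C(C)c2c(F)cccc2F)nc(N(C)C)[nH]c1=O`) gives > 17000 nM, which is a limit and not a number. Compound 2 (`CCc1c(C(C)c2c(F)cccc2F)nc(N(C)C)[nH]c1=O`) gives > 81000 nM, which is also a limit. Compound 1 therefore has no exact position, and neither value in hand offers a numerical reference.

Compound 3 (`Cc1c(C(C)c2c(F)cccc2F)nc(N2CCC(C)CC2)[nH]c1=O`) carries 4-methylpiperidin-1-yl in place of dimethylamino on an aromatic carbon, between two ring nitrogen atoms: 4-methylpiperidin-1-yl in place of dimethylamino on an aromatic carbon.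

Going by the values given here, the only measured step is a step that the two limits leave unreadable from compound 1 to compound 2. It concerns a methyl in place of hydrogen on a saturated chain carbon, not the group exchanged here, and it has no readable size. Among the compounds with values here, no measured step therefore sets a size or direction for this exchange. In this assay, no clear step beyond the scatter is expected, although the uncertainty is wide and compound 3 may also return only a limit.

The step is estimated as a step that the limit leaves unreadable from compound 1 to compound 3. For compound 3, the expected value is 25000 nM, with an estimated range of 7000 nM to 90000 nM.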

Compound 3, half-maximal cytotoxic concentration: 54000 nM
Estimate against measurement, compound 3: 2.2-fold (0.33 log units) below, within the range that was stated.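

Going by these compounds alone, no step from compound 1 to compound 3 can be read in this assay, because the value of compound 1 is a limit and not a number: the limit of > 17000 nM in this assay, at which 1 of the 3 values shown sits. The compounds shown leave open the size and direction of the change when 4-methylpiperidin-1-yl replaces dimethylamino on the core of compound 1.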